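Cyclohexene-dicarboximide series: ester for propargyl ether

The source may report more compounds than this note shows. Statements on the series, on what has been measured and on what is new or still open speak of the compounds shown alone.

Compound 1 `O=C1C2=C(CCCC2)C(=O)N1c1ccccc1`: 1260 nM
Compound 2 `C#CCOc1cc(N2C(=O)C3=C(CCCC3)C2=O)ccc1Cl`: 0.794 nM

Both measured compounds share the same imide core; compound 1 carries an unsubstituted phenyl, compound 2 a substituted one. In an assay on isolated protein (Echinochloa esculenta) for inhibition of protoporphyrinogen oxidase, chloroplastic (Oryza sativa subsp. japonica), using a Dixon plot, with a stated time of 5 min (a lower number here means a stronger inhibitor, a higher number a weaker inhibitor), compound 1 gives 1260 nM, while compound 2 gives 0.794 nM, the lowest of the two numbers and far beyond the scatter from compound 1. Among the measured compounds shown here, no single-change step between measured compounds is available, so the effect of the substitution pattern on the phenyl cannot be separated into parts.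

Compound 3 `CC(C)OC(=O)c1cc(N2C(=O)C3=C(CCCC3)C2=O)ccc1Cl` differs from compound 2 in one place: isopropoxycarbonyl in place of propargyloxy on an aromatic carbon, on an aromatic carbon of the six-membered aromatic ring, ortho to a chloro group and meta to a large group. The aromatic chloro and the imide core are kept.

For the measured compounds named here, with only two numbers in hand, the step from compound 2 to compound 3 can only be judged by analogy of size and kind of the substituent. Compound 3 is expected to remain a strong inhibitor in this assay, with a modest loss estimated as a 3.8-fold higher number from compound 2 to compound 3 (0.58 log units; beyond the scatter). The estimate for compound 3 is 3 nM, with a range from 0.5 nM to 20 nM.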

Compound 3, half-maximal inhibitory concentration: 2 nM
Estimate against measurement, compound 3: 1.5-fold (0.18 log units) above, and the stated range covers the measured number.
By their numbers in this assay, from the lowest: compound 2; then compound 3; then compound 1.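

In this assay, the aromatic carbon ortho to a chloro group and meta to a large group accepts a second, quite different substituent, with a 2.5-fold higher number from compound 2 to compound 3 (0.40 log units; beyond the scatter) when isopropoxycarbonyl replaces propargyloxy. The triple bond of propargyloxy is therefore not required for a strong number in this pair, since compound 3, with a carbonyl-containing ester and no triple bond, gives 2 nM. The data offer no measured property or other basis for explaining the modest difference between these two groups.

This single step combines two changes, the link to the ring and the alkyl part, and an isopropoxy ether or a propargyl ester would be needed to separate them. From the compounds shown here alone, how far this position tolerates other kinds of group also remains open, for example a carboxylic acid, an amine or a longer-chain ester, as does the contribution of the chloro group, which stays constant across this step.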